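The compounds below may be only part of what the source reports. "The series", "measured", "known", "first", "only" and "open" are said of these compounds alone.

Compound 1 `COc1ccc2c(=O)c(/C=C/C(=O)Nc3cc(C)ccc3C)coc2c1` — > 200000 nM
Compound 2 `Cc1ccc(CNC(=O)/C=C/c2coc3cc(O)ccc3c2=O)cc1` — > 200000 nM
Compound 3 `COc1ccc2c(=O)c(/C=C/C(=O)NCc3ccc(F)cc3)coc2c1` — > 200000 nM

Of the compounds shown here, three have been measured in a functional assay on L02 cells (Homo sapiens) for inhibition, read by MTT assay, with a stated time of 48 h (on this read-out higher numbers stand for weaker inhibition and lower numbers for stronger inhibition), and none of them gave a number. Compound 1 sits at a limit of the assay, > 200000 nM. Compound 2 likewise sits at a limit, > 200000 nM. Compound 3 also sits at a limit, > 200000 nM, so its standing relative to the other two cannot be read from these values. The one single-point step among the measured compounds, a step that the two limits leave unreadable from compound 1 to compound 3, is unreadable for the same reason, as shown by the limit of > 200000 nM in this assay, at which 3 of the 3 values shown sit.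

Compound 4 `COc1ccc2c(=O)c(/C=C/C(=O)NCc3ccc(C)cc3)coc2c1` has not yet been measured in this assay. It differs from compound 3 by methyl in place of fluoro on an aromatic carbon.

Among the measured compounds shown here, no measured step speaks to this exchange, and the three values available all rest at the same limit. Because compound 3 gives > 200000 nM, a limit of the assay, the expectation for compound 4 is that the step of a number no higher from compound 3 to compound 4 (the limit leaves the size open) is none beyond the scatter, with compound 4 most likely reported at the limit as well. Compound 4 is accordingly estimated at 200000 nM, within a range from 100000 nM to 1000000 nM.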

Compound 4, half-maximal inhibitory concentration: > 200000 nM
Compound 4 gave a limit, no number; the forecaster's own chance of this, stated with the estimate: 85%; the middle value lies on the limit itself.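

In this assay compound 4 gives > 200000 nM and this is a limit, not a number. Its steps from compound 1, compound 2 and compound 3 cannot be read, because all four compounds rest on one shared limit: the limit of > 200000 nM in this assay, at which 4 of the 4 values shown sit.

The compounds shown leave open whether, in this assay, any of these exchanges changes inhibition at all.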